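A few compounds are considered here, and "the series" means these few. Any claim that something is new, unique, unknown or untested is made for them only; others in the source may bear on it.

In a functional assay on A549 cells (Homo sapiens) for antiproliferative activity, read by MTT assay, with a stated time of 48 h (a lower number here means a stronger inhibitor, a higher number a weaker inhibitor), compound 2 `COc1ccc(/C=C/c2cc(OC)cc(OC)c2/C=C/C(=O)c2ccc(OC)cc2)cc1` gives 4.5 ug/mL. Its only companion so far, compound 1 `COc1ccc(/C=C/c2cc(OC)cc(OC)c2/C=C/C(=O)c2ccc(N)cc2)cc1`, gives 3.8 ug/mL, and the step of a 1.2-fold higher number from compound 1 to compound 2 (0.07 log units; within the scatter) leaves the two indistinguishable. Compound 3 `CCN(CC)c1ccc(C(=O)/C=C/c2c(/C=C/c3ccc(OC)cc3)cc(OC)cc2OC)cc1` differs from compound 2 in one place: diethylamino in place of methoxy on an aromatic carbon. For the measured compounds named here, the one measured step exchanges the group at that same place and stayed within the scatter, so the expected step of no change at the digits printed from compound 2 to compound 3 (within the scatter) is likewise small, with no direction beyond the scatter. Compound 3 is therefore expected to give 4.5 ug/mL, with a likely range from 2 ug/mL to 10 ug/mL.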

Compound 3, half-maximal inhibitory concentration: 5.4 ug/mL
Beside the measured number, compound 3's estimate is 1.2-fold (0.08 log units) below it; low and high end bracket the measured number.
By their numbers in this assay, from the lowest: compounds 1, 2 and 3 (each within the scatter of the next).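

In this assay, the place on the aromatic ring takes diethylamino, with 5 heavy atoms in place of the 2 of methoxy, and the measured step is a 1.2-fold higher number from compound 2 to compound 3 (0.08 log units; within the scatter). Set against the small amino group, the same diethylamino gives a 1.4-fold higher number from compound 1 to compound 3 (0.15 log units; within the scatter). So amino, methoxy and diethylamino cannot be told apart at this place, and no evidence here bears on this result. The compounds shown leave open whether a carboxylic acid or a fluorine atom at this place would separate from these three. They also leave open how changes elsewhere on the shared core would read.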